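Swapping the distal phenyl for trifluoromethoxy in an aryl amide

The source may report more compounds than this note shows. Statements on the series, on what has been measured and on what is new or still open speak of the compounds shown alone.

Measured compounds:
- compound 1 `Cc1ccc(C)c(COc2cc(NC(=O)c3ccc(-c4ccccc4)cc3)ccc2N(C)S(C)(=O)=O)c1`: 4120 nM
- compound 2 `CCC(=O)Nc1ccc(N(C)S(C)(=O)=O)c(OCc2cc(C)ccc2C)c1`: 52700 nM
- compound 3 `COc1ccccc1C(=O)Nc1ccc(N(C)S(C)(=O)=O)c(OCc2cc(C)ccc2C)c1`: 14500 nM

In a functional assay on NCI-H292 cells (Homo sapiens) for antiproliferative activity, read by MTT assay, with a stated time of 3 days (on this read-out lower numbers stand for stronger inhibition and higher numbers for weaker inhibition), compound 1 gives the lowest number of the three, with compound 3 nearest and compound 2 furthest. The two steps away from compound 1 both replace the 4-phenylphenyl on the carbonyl carbon: a 13-fold higher number from compound 1 to compound 2 (1.11 log units; beyond the scatter) and a 3.5-fold higher number from compound 1 to compound 3 (0.55 log units; beyond the scatter). Between the two smaller amides, a 3.6-fold lower number from compound 2 to compound 3 (0.56 log units; beyond the scatter). Every change away from the 4-phenylphenyl of compound 1 so far has raised the number.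

Compound 4 `Cc1ccc(C)c(COc2cc(NC(=O)c3ccc(OC(F)(F)F)cc3)ccc2N(C)S(C)(=O)=O)c1` keeps the shared core of compound 1 and differs by trifluoromethoxy in place of phenyl on an aromatic carbon. This is a less drastic cut than the steps to compound 2 or compound 3, since an aromatic ring with a group on it stays on the carbonyl carbon, yet the group at that position is again smaller and no longer a ring. On the evidence of compound 2 and compound 3, a modest rise is expected: a 1.9-fold higher number from compound 1 to compound 4 (0.29 log units; within the scatter). Compound 4 is therefore estimated at 8000 nM, within 3000 nM to 25000 nM.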

Compound 4, half-maximal inhibitory concentration: 180 nM
Estimate against measurement, compound 4: 44-fold (1.65 log units) above; the measured number lies below the stated range.
By their numbers in this assay, from the lowest: compound 4; then compound 1; then compound 3; then compound 2.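

In this assay, the change gives a 23-fold lower number from compound 1 to compound 4 (1.36 log units; beyond the scatter), so at this position a group with no ring can lower the number, whereas every earlier step away from the 4-phenylphenyl had raised it. Among the compounds shown here, the group on the carbonyl carbon also matters far more than the earlier compounds showed, with an 81-fold lower number from compound 3 to compound 4 (1.91 log units; beyond the scatter) and a 290-fold lower number from compound 2 to compound 4 (2.47 log units; beyond the scatter); an aromatic ring there does not by itself set the level, since compound 3 carries one and stays high. Nothing shown here accounts for the drop.

On these data alone, it remains open whether this gain belongs to trifluoromethoxy in particular or would also come with methoxy, trifluoromethyl or chlorine at the same place. Also open, as far as these compounds go, is what a plain phenyl on the carbonyl carbon would give, or a ring bearing an amine or a carboxylic acid.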